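Removing one sulfonamide arm from a bis-sulfonamide benzoxazole

This account rests on a few compounds, and the source may have more. Where it says the series, first, only, none or still open, it means among the compounds named here.

Compound 1 `O=S(=O)(Nc1ccc(-c2nc3cc(NS(=O)(=O)c4ccccc4)ccc3o2)cc1)c1ccccc1`: 80000 nM
Compound 2 `O=S(=O)(Nc1ccc(-c2nc3cc(NS(=O)(=O)c4cccs4)ccc3o2)cc1)c1cccs1`: 40000 nM
Compound 3 `O=S(=O)(Nc1ccc(-c2nc3ccccc3o2)cc1)c1cccs1`: 63000 nM

Of the compounds shown here, three have been measured in an assay on cells for inhibition of HSP60/HSP10 (Homo sapiens), with a stated time of 60 min; on this read-out higher numbers stand for weaker inhibition and lower numbers for stronger inhibition. Compound 2 holds the lowest of the three numbers, though compound 3 sits only a 1.6-fold higher number from compound 2 to compound 3 (0.20 log units; within the scatter) away and compound 1 also lies within the scatter of it, so none of the three can be set apart from the others.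

Compound 4 `O=S(=O)(Nc1ccc2oc(-c3ccccc3)nc2c1)c1cccs1` has not yet been measured. It differs from compound 2 in one place: hydrogen in place of ((thiophen-2-yl)sulfonyl)amino on an aromatic carbon. For the measured compounds named here, the one measured step that bears on this change is the one from compound 2 to compound 3, where the same group was replaced by hydrogen on the other ring of the shared core, giving a 1.6-fold higher number from compound 2 to compound 3 (0.20 log units; within the scatter). Since that removal left the number within the scatter, the removal in compound 4 is expected to do much the same, a step of about a 1.4-fold higher number from compound 2 to compound 4 (0.14 log units; within the scatter). Compound 4 is therefore estimated at 55000 nM, with a range from 20000 nM to 150000 nM.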

Compound 4, half-maximal inhibitory concentration: 90000 nM
The estimate for compound 4 lay 1.6-fold (0.21 log units) below the measured number; the range from low to high includes it.
By their numbers in this assay, from the lowest: compounds 2, 3, 1 and 4 (each within the scatter of the next, the first and the last beyond it).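

In this assay, replacing the ((thiophen-2-yl)sulfonyl)amino group with hydrogen at this aromatic carbon, para to a large group, gives a 2.3-fold higher number from compound 2 to compound 4 (0.35 log units; beyond the scatter) and so a modest loss, the only listed step that passes the scatter. For the compounds shown here, the same replacement at the other place on the shared core gave a 1.6-fold higher number from compound 2 to compound 3 (0.20 log units; within the scatter) and did not pass it, so this position is the first to show a measurable, though small, need for the group. Nothing measured here accounts for that contrast between the two places.

On these data alone, it remains open whether the ((thiophen-2-yl)sulfonyl)amino group is needed in full at this carbon, or whether a plain amine or an acetamide there would keep the number of compound 2 at 40000 nM in this assay as well. As far as these compounds go, the effect of removing both arms from the shared core also stays unknown.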